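This account rests on a few compounds, and the source may have more. Where it says the series, first, only, none or still open, it means among the compounds named here.

Compound 1 `COc1cc2ncnc(Nc3ccc(Cl)c(C(F)(F)F)c3)c2cc1OCCCCC(=O)Nc1ccc(S(N)(=O)=O)cc1` gives 9270 nM in a functional assay on A549 cells (Homo sapiens) for antiproliferative activity, read by MTT assay, with a stated time of 72 h; on this read-out lower numbers stand for stronger inhibition and higher numbers for weaker inhibition. Compound 2 `COc1cc2ncnc(Nc3cccc(F)c3)c2cc1OCCCCC(=O)Nc1ccc(S(N)(=O)=O)cc1` reaches only the limit of this assay, > 40000 nM. Compound 3 `C#Cc1cccc(Nc2ncnc3ccc(NC(=S)Nc4ccc(S(N)(=O)=O)cc4)cc23)c1` likewise stops at the limit of this assay, > 40000 nM.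

Compound 3 therefore stands among the two values at the limit (the limit of > 40000 nM in this assay, at which 2 of the 3 values shown sit), giving only a floor for its weakness. Compound 4 `NS(=O)(=O)c1ccc(NC(=S)Nc2ccc3ncnc(Nc4cccc(Cl)c4F)c3c2)cc1` differs from it by 3-chloro-2-fluorophenyl in place of 3-ethynylphenyl on a nitrogen on an aromatic ring. Within the data shown here, the one measured step at that same nitrogen, an at least 4.3-fold higher number from compound 1 to compound 2 (0.63 log units; beyond the scatter), shows that swapping this aryl group can shift the number well beyond the scatter. Among the measured compounds shown here, no measured pair shows the present swap itself. The estimated step of an at least 1.3-fold lower number from compound 3 to compound 4 (0.12 log units; that floor lies within the scatter) leaves compound 4 weak, and compound 4 is expected near 30000 nM, between 8000 nM and 40000 nM, with a fair chance of another limit.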

Compound 4, half-maximal inhibitory concentration: > 40000 nM
Compound 4: no number, only a limit; the forecaster's own chance of this, stated with the estimate: 60%; at least 1.3-fold (0.12 log units) between middle value and limit.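

Among these compounds, compound 3 and compound 4 both stop at a limit rather than a number, so no step between them can be read: the limit of > 40000 nM in this assay, at which 3 of the 4 values shown sit. On these data alone, whether 3-chloro-2-fluorophenyl and 3-ethynylphenyl truly differ in this assay stays open.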